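Swapping fluoro for methoxy on two related chromone amides

The source may hold more compounds than are shown below. What is called first, only, known or untested is meant among the compounds shown, and "the series" means these compounds.

Measured compounds:
compound 1, `O=C(COc1ccc2oc(-c3ccccc3)cc(=O)c2c1)Nc1ccc(F)cc1`, 1470 nM
compound 2, `COc1ccc(NC(=O)COc2ccc3oc(-c4ccccc4)cc(=O)c3c2)cc1`, 840 nM
compound 3, `O=C(COc1ccc2c(=O)cc(-c3ccccc3)oc2c1)Nc1ccc(F)cc1`, 5770 nM

All three were tested in a functional assay on NCI-H661 cells (Homo sapiens) for antiproliferative activity, read by MTT assay, with a stated time of 72 h; a lower number here means a stronger inhibitor of growth, a higher number a weaker inhibitor of growth. Compound 1 and compound 2 share one core and differ only at the outer ring: methoxy in place of fluoro on an aromatic carbon. This change gave a 1.8-fold lower number from compound 1 to compound 2 (0.24 log units; within the scatter), so the two numbers cannot be told apart with confidence. Compound 3 is built from the same atoms as compound 1, joined differently, and the difference between the two cores is not broken down here. Compound 3 gives the highest number of the three, and its gap to compound 1 is beyond the scatter, so on the evidence at hand the core of compound 3 is the weaker growth inhibitor.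

Compound 4, `COc1ccc(NC(=O)COc2ccc3c(=O)cc(-c4ccccc4)oc3c2)cc1`, has not yet been measured. It differs from compound 3 in the same way that compound 2 differs from compound 1: methoxy in place of fluoro on an aromatic carbon. The place is described in the same words for both pairs, so this is the same change on a different core.

Going by the values given here, because the first instance of this change gave a 1.8-fold lower number from compound 1 to compound 2 (0.24 log units; within the scatter), the step from compound 3 to compound 4 is expected to be of similar size, a 1.7-fold lower number from compound 3 to compound 4 (0.24 log units; within the scatter), with the caveat that a single earlier example on a different core is thin ground. Compound 4 is accordingly estimated at 3300 nM, within a range from 1500 nM to 7500 nM in this assay.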

Compound 4, concentration for 50% growth inhibition: 5500 nM
Estimate against measurement, compound 4: 1.7-fold (0.22 log units) below; measured number inside the range.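

Putting methoxy in place of fluoro on the core of compound 3 gave a 1.0-fold lower number from compound 3 to compound 4 (0.02 log units; within the scatter), so the two compounds cannot be told apart in this assay. Set beside the earlier example, the two steps do not differ by more than these measurements can resolve: the same change on two cores in this assay, a 1.8-fold lower number (0.24 log units; within the scatter) from compound 1 to compound 2 and a 1.0-fold lower number (0.02 log units; within the scatter) from compound 3 to compound 4, 1.7-fold (0.22 log units) apart, within the scatter of two such steps. Going by these compounds alone, this shows that, on these two cores, the change produced no step beyond the scatter, but it does not show that methoxy and fluoro are interchangeable in general, and with only two small steps, it cannot establish that the change has any real effect on either core.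

The compounds shown leave open whether a different group on the same aromatic carbon, such as chloro, a hydroxyl or a dimethylamino group, would give a step beyond the scatter on either core. They also leave open whether a change elsewhere in the molecule, such as a longer chain in place of the one that links the amide to the core, would carry from one core to the other.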